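A few compounds are considered here, and "the series" means these few. Any claim that something is new, unique, unknown or untested is made for them only; others in the source may bear on it.

Measured so far:
compound 1 `COc1ccc2c(c1)c(-c1cc(C(F)(F)F)c(C#N)c(-c3cn(S(=O)(=O)c4ccc(C)cc4)c4ccc(OC)cc34)n1)cn2S(=O)(=O)c1ccc(C)cc1`: 25.2%
compound 2 `COc1ccc2c(-c3cc(C(F)(F)F)c(C#N)c(-c4cn(S(=O)(=O)c5ccc(C)cc5)c5cc(OC)ccc45)n3)cn(S(=O)(=O)c3ccc(C)cc3)c2c1`: 13.3%
compound 3 `Cc1ccc(S(=O)(=O)n2cc(-c3cc(C(F)(F)F)cc(-c4cn(S(=O)(=O)c5ccc(C)cc5)c5cc(Br)ccc45)n3)c3ccc(Br)cc32)cc1`: 32%

All three numbers come from a functional assay on A549 cells (Homo sapiens) for inhibition, tested at 10 uM; on this read-out higher numbers stand for a stronger effect at the one concentration tested and lower numbers for a weaker effect. Compound 2 stands lowest of the three; compound 1 sits higher by a gap beyond the scatter, and compound 3 higher still, also beyond the scatter. Compound 4 `COc1ccc2c(-c3cc(C(F)(F)F)cc(-c4cn(S(=O)(=O)c5ccc(C)cc5)c5cc(OC)ccc45)n3)cn(S(=O)(=O)c3ccc(C)cc3)c2c1` is the unmeasured partner of compound 2; the change is hydrogen in place of cyano on an aromatic carbon. For the measured compounds named here, compound 3 also carries hydrogen at that place, but differs elsewhere as well, so no single-change step is known for this exchange. The step from compound 2 to compound 4 in this assay is expected to be a modest rise, a number 8.7 percentage points higher from compound 2 to compound 4 (within the scatter), since compound 3 gives 32% where compound 2 gives 13.3%. Compound 4 is therefore estimated at 22%, with a range from 6% to 40%.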

Compound 4, a percentage reported as inhibition, at one concentration (the size of the read-out at that concentration, not a potency): 28.8%
Compound 4: middle estimate off by 6.8 percentage points, on the low side; measured number inside the range.
By their numbers in this assay, from the lowest: compound 2; then compounds 1, 4 and 3 (each within the scatter of the next).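

Hydrogen in place of cyano, on the aromatic carbon ortho to a trifluoromethyl group, now has a single-change reading: in this assay the result is a number 15.5 percentage points higher from compound 2 to compound 4 (beyond the scatter). On this core, cyano at this place is therefore not required for the effect at the one concentration tested, and the hydrogen partner reads higher. Nothing available on these compounds accounts for the step.

On these data alone, whether the same exchange gives a similar step on the core of compound 1 remains open. Also open, as far as these compounds go, is what an amine, a carboxamide or a carboxylic acid would give on this carbon.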